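Ethoxy for ethylsulfanyl on a steep series

The source may hold more compounds than are shown below. What is called first, only, known or untested is meant among the compounds shown, and "the series" means these compounds.

In a functional assay on MV4-11 cells (Homo sapiens) for inhibition, read by resazurin assay, with a stated time of 72 h (a higher number here means a weaker inhibitor of growth, a lower number a stronger inhibitor of growth), compound 1 `COc1ccc(Nc2nccc(-c3sc(N(C)C)nc3C)n2)c(OC)c1` gives 170 nM, compound 2 `CCCSc1nc(C)c(-c2ccnc(Nc3ccc(OC)cc3OC)n2)s1` gives 2240 nM and compound 3 `CCSc1nc(C)c(-c2ccnc(Nc3ccc(OC)cc3OC)n2)s1` gives 32400 nM. Compound 3 therefore has the highest number of the three and is the weakest inhibitor of growth here, with both of its steps beyond the scatter.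

Compound 4 `CCOc1nc(C)c(-c2ccnc(Nc3ccc(OC)cc3OC)n2)s1` has ethoxy in place of ethylsulfanyl on an aromatic carbon, next to the ring nitrogen and the ring sulfur: ethoxy in place of ethylsulfanyl on an aromatic carbon.

Within the data shown here, no measured pair makes this exchange, so the evidence is indirect. All three measured steps involve the same carbon, and all are large: a 13-fold higher number from compound 1 to compound 2 (1.12 log units; beyond the scatter), a 190-fold higher number from compound 1 to compound 3 (2.28 log units; beyond the scatter) and a 14-fold higher number from compound 2 to compound 3 (1.16 log units; beyond the scatter). The last of these is only a change in chain length, so this assay responds strongly to small edits at this carbon. Compound 3 at 32400 nM sits at the top of the measured span, so a step towards a lower number is more likely than a further rise, though the size remains poorly defined. The expected change is a 6.5-fold lower number from compound 3 to compound 4 (0.81 log units; beyond the scatter), a large step with wide uncertainty. For compound 4 the estimate is 5000 nM, with an expected range of 700 nM to 35000 nM.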

Compound 4, concentration for 50% growth inhibition: 3890 nM
The estimate for compound 4 lay 1.3-fold (0.11 log units) above the measured number; measured number inside the range.
By their numbers in this assay, from the lowest: compound 1; then compounds 2 and 4 (each within the scatter of the next); then compound 3.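

Notes on this carbon: in this assay, with the two-carbon chain kept and only the linking atom exchanged, ethoxy for ethylsulfanyl gives an 8.3-fold lower number from compound 3 to compound 4 (0.92 log units; beyond the scatter), the first direct reading of sulfur against oxygen at this position, and it lies beyond the scatter. The high number of compound 3 is therefore not shared by every two-carbon chain at this carbon, and ethoxy lands level with the longer propylsulfanyl, at a 1.7-fold higher number from compound 2 to compound 4 (0.24 log units; within the scatter), which is within the scatter. The exchange closes only part of the gap to dimethylamino, since a 23-fold higher number from compound 1 to compound 4 (1.36 log units; beyond the scatter) remains large, so among the four compounds dimethylamino still gives the lowest number.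

No measurement shown here accounts for any of these steps.
Propoxy would show whether lengthening the chain on oxygen moves the number as it does on sulfur, where the step is a 14-fold higher number from compound 2 to compound 3 (1.16 log units; beyond the scatter), and methoxy would extend the same comparison to a shorter chain. As far as these compounds go, whether diethylamino, pyrrolidine or a primary amine keeps the lower number of compound 1 also remains open.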